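The source may report more compounds than this note shows. Statements on the series, on what has been measured and on what is new or still open speak of the compounds shown alone.

Compound 1 `COCc1ncc2cnnc(SC)n12` gives > 48000 nM in a functional assay for inhibition, with Homo sapiens as the target (on this read-out lower numbers stand for stronger inhibition and higher numbers for weaker inhibition), which is a limit of the assay and not a number.
Compound 2 `COCc1ncc2cnnc(S)n12` gives > 48000 nM, likewise a limit.
Compound 3 `COCc1ncc2cnnc(NCCN(C)C)n12` gives > 48000 nM, also a limit.

Compound 1 therefore stands at the limit only, as do the other two values (the limit of > 48000 nM in this assay, at which 3 of the 3 values shown sit). The steps a step that the two limits leave unreadable from compound 1 to compound 2, a step that the two limits leave unreadable from compound 1 to compound 3 and a step that the two limits leave unreadable from compound 2 to compound 3 consequently carry no readable size. Compound 4 `CCCc1ncc2cnnc(SC)n12` differs from compound 1 by ethyl in place of methoxy on a saturated chain carbon bound to an aromatic carbon. Among the compounds with values here, none of the measured steps touches this position; all of them concern the group on the aromatic carbon, and none yields a size. No movement beyond the scatter is expected in this assay for compound 4, which is estimated at 60000 nM (range 20000 nM to 200000 nM), most likely again reported as a limit. The expected step that the limit leaves unreadable from compound 1 to compound 4 is accordingly none beyond the scatter.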

Compound 4, half-maximal inhibitory concentration: > 48000 nM
Compound 4 ended at the assay's limit; the forecaster's own chance of this, stated with the estimate: 85%; the middle value is on the limit's open side.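

No step can be read between compound 1 and compound 4, since both values are limits and not numbers: the limit of > 48000 nM in this assay, at which 4 of the 4 values shown sit.

The compounds shown leave open which change to the shared core, if any, would give a measurable value in this assay.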